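Changing the Aryl Group on the Amide Nitrogen

The compounds below may be only part of what the source reports. "The series", "measured", "known", "first", "only" and "open" are said of these compounds alone.

Compound 1, `CCOC(=O)c1c(O)c2cccnc2n(-c2ccccc2)c1=O`, gives 15.5% in a functional assay on the whole organism for inhibition, with Rattus norvegicus as the target, read by cytopathic effect and paw edema, at a dose of 100 mg/kg by the oral route; a higher number here means more inhibition at the dose given (going by the name of the read-out), a lower number less inhibition.
Compound 2, `O=C(Nc1ccc(Cl)cc1)c1c(O)c2cccnc2n(-c2ccccc2)c1=O`, gives 2.5% in this assay.

Compound 2 stands lowest of the two, below compound 1 by a number 13 percentage points lower from compound 1 to compound 2 (beyond the scatter). Compound 3 is `COc1ccc(NC(=O)c2c(O)c3cccnc3n(-c3ccccc3)c2=O)cn1`; the change is 6-methoxypyridin-3-yl in place of 4-chlorophenyl on an amide-type nitrogen. Within the data shown here, the only measured step, a number 13 percentage points lower from compound 1 to compound 2 (beyond the scatter), altered the group on the carbonyl carbon itself, not the ring on the amide nitrogen, so it bears only loosely here. No step beyond the scatter is expected, giving an estimated a number 3.5 percentage points higher from compound 2 to compound 3 (within the scatter). Compound 3 is therefore expected to reach about 6%, between 0% and 22%.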

Compound 3, a percentage reported as inhibition, in the whole organism at one dose (the size of the read-out at that dose, not a potency): -10.2%
Beside the measured number, compound 3's estimate is 16.2 percentage points above it; measured number outside the range, below it.
By their numbers in this assay, from the lowest: compound 3; then compound 2; then compound 1.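

On an amide-type nitrogen the aryl group itself counts in this assay: 6-methoxypyridin-3-yl in place of 4-chlorophenyl gives a number 12.7 percentage points lower from compound 2 to compound 3 (beyond the scatter), whereas the earlier step changed only the group on the carbonyl carbon. (6-Methoxypyridin-3-yl)amino in place of ethoxy gives a number 25.7 percentage points lower from compound 1 to compound 3 (beyond the scatter), so this amide also stands under the ester. Nothing available explains either fall. Going by these compounds, this swap changes the ring and its substituent together, so which part matters stays open. A 4-methoxyphenyl group or a pyridin-3-yl group on the same nitrogen would separate the two.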